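The compounds below may be only part of what the source reports. "The series", "measured", "known", "first", "only" and "open" are said of these compounds alone.

Three compounds have been measured in an assay on HEK293 cells for inhibition of N-acylethanolamine-hydrolyzing acid amidase (Rattus norvegicus), read by LC-MS, with a stated time of 30 min; a lower number here means a stronger inhibitor, a higher number a weaker inhibitor:
Compound 1 `Cc1ccccc1CCCCCCC(=O)N1CCCC1` gives 68400 nM.
Compound 2 `O=C(CCc1ccc(-c2ccccc2F)cc1)N1CCCC1` gives 2800 nM.
Compound 3 `COc1cccc(CCCCCCC(=O)N2CCCC2)c1` gives > 100000 nM, which is a limit of the assay and not a number.

Among the two values that are numbers, compound 2 has the lowest, and compound 1 lies beyond the usual scatter above it. The value of compound 3 sits at the limit of > 100000 nM in this assay, at which 1 of the 3 values shown sits. The next compound, compound 4 `O=C(CCc1ccc(OC2CCCCC2)cc1)N1CCCC1`, is not yet measured. It differs from compound 2 in one place: cyclohexyloxy in place of 2-fluorophenyl on an aromatic carbon. Among the compounds with values here, no measured pair shows this change, so its size is open. The step is expected to be a modest weakening, a 1.8-fold higher number from compound 2 to compound 4 (0.25 log units; within the scatter). In this assay compound 4 is estimated at 5000 nM, with a range from 1000 nM to 30000 nM.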

Compound 4, half-maximal inhibitory concentration: 700 nM
Compound 4: the middle estimate sits 7.1-fold (0.85 log units) above what was measured; measured number outside the range, below it.
By their numbers in this assay, from the lowest: compound 4; then compound 2; then compound 1. At a limit, above all of these: compound 3.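

Cyclohexyloxy in place of 2-fluorophenyl on this aromatic carbon gives a 4.0-fold lower number from compound 2 to compound 4 (0.60 log units; beyond the scatter) in this assay, so an aromatic ring is not required at this position. Both groups have the same number of heavy atoms, but they differ in ring type and in the oxygen, which adds a hydrogen-bond acceptor. Nothing available shows which of these differences accounts for the step.

As far as these compounds go, it remains open whether the oxygen itself matters, which a cyclohexyl ring joined directly to the aromatic carbon would test. A phenoxy group would likewise separate the effect of the oxygen from that of the ring type.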